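Working notes: branched alkyl exchange at the double-bonded nitrogen

The compounds below may be only part of what the source reports. "The series", "measured", "known", "first", "only" and "open" are said of these compounds alone.

Two compounds have numbers in a functional assay on the whole organism (blood, strain Wistar-Okamoto) with Rattus norvegicus as the target, with a stated time of 5 days; a lower number here means that less compound is needed, a higher number that more compound is needed for the effect. Compound 1 `CC(/N=C(/NC#N)Nc1cccnc1)C(C)(C)C` gives 1 mg/kg in this assay. Compound 2 `CC(C)(C)C/N=C(\NC#N)Nc1ccncc1` gives 5 mg/kg and stands highest of the two, with compound 1 the nearest at a lower number, a gap beyond the scatter; the two differ in more than one place, so no single step can be read between them. Compound 3 `CC(C)CC(C)/N=C(\NC#N)Nc1ccncc1` is not yet measured. It differs from compound 2 by 1,3-dimethylbutyl in place of neopentyl on a double-bonded nitrogen. Among the measured compounds shown here, no measured pair shows this change, so only a modest step toward a lower number is expected, about a 1.7-fold lower number from compound 2 to compound 3 (0.22 log units; within the scatter). For compound 3 the estimate is 3 mg/kg, within 1 mg/kg to 10 mg/kg.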

Compound 3, minimum effective dose: 35 mg/kg
Beside the measured number, compound 3's estimate is 12-fold (1.07 log units) below it; the measured number lies above the stated range.
By their numbers in this assay, from the lowest: compound 1; then compound 2; then compound 3.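

At this position the alkyl groups are not interchangeable: 1,3-dimethylbutyl in place of neopentyl on a double-bonded nitrogen gives a 7.0-fold higher number from compound 2 to compound 3 (0.85 log units; beyond the scatter). Among the compounds shown here, this is the only single-place step so far, and it shows that this change alone moves the dose needed beyond the scatter. No measurement shown offers a reason for this step. Going by these compounds, how isopropyl or cyclohexyl on this nitrogen would compare with neopentyl stays open. For the compounds shown here, compound 1 differs from compound 2 and compound 3 in more than one place, so no step to it can be read.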